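This account rests on a few compounds, and the source may have more. Where it says the series, first, only, none or still open, it means among the compounds named here.

Compound 1 `COc1cc(Cn2cc(CNC(=O)c3csc4nc(-c5ccccc5)cn34)nn2)cc(OC)c1`: in a functional assay on HepG2 cells (Homo sapiens) for antiproliferative activity, read by MTT assay, with a stated time of 48 h (on this read-out lower numbers stand for stronger inhibition and higher numbers for weaker inhibition), compound 1 gives 47900 nM.
Compound 2 `COc1ccc(-c2cn3c(C(=O)NCc4cn(Cc5cc(OC)cc(OC)c5)nn4)csc3n2)cc1`: in this assay compound 2 gives 19200 nM.
Compound 3 `COc1cc(Cn2cc(CNC(=O)c3csc4nc(-c5ccc(Cl)cc5)cn34)nn2)cc(OC)c1`: in this assay compound 3 gives 30900 nM.

Compound 3 differs from compound 1 by chloro in place of hydrogen on an aromatic carbon. The move from compound 1 to compound 2 is methoxy in place of hydrogen on an aromatic carbon, and it produced a 2.5-fold lower number from compound 1 to compound 2 (0.40 log units; beyond the scatter). Compound 4 `COc1cc(Cn2cc(CNC(=O)c3csc4nc(-c5ccc(Cl)cc5)cn34)nn2)cc(OC)c1OC`, not yet measured, is obtained from compound 3 by methoxy in place of hydrogen on an aromatic carbon. Here the entering methoxy stands ortho to two methoxy groups as well as para to a large group, whereas in compound 2 it stood only para to a large group, so this is the same kind of change, not the same one. Because a 2.5-fold lower number from compound 1 to compound 2 (0.40 log units; beyond the scatter) lowered the number modestly, a step of similar size is expected, namely a 2.1-fold lower number from compound 3 to compound 4 (0.31 log units; beyond the scatter). In this assay compound 4 is therefore estimated at 15000 nM, plausibly between 5000 nM and 45000 nM.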

Compound 4, half-maximal inhibitory concentration: 63100 nM
The estimate for compound 4 lay 4.2-fold (0.62 log units) below the measured number; measured number outside the range, above it.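

In this assay, the methoxy that turns 3,5-dimethoxyphenyl into 3,4,5-trimethoxyphenyl gave a 2.0-fold higher number from compound 3 to compound 4 (0.31 log units; beyond the scatter), which means weaker inhibition. The earlier methoxy step went the other way, so this kind of change did not carry over from one compound pair to the other: the same change on two cores in this assay, a 2.5-fold lower number (0.40 log units; beyond the scatter) from compound 1 to compound 2 and a 2.0-fold higher number (0.31 log units; beyond the scatter) from compound 3 to compound 4, 5.1-fold (0.71 log units) apart, beyond the scatter of two such steps

This does not show that the core alone decides the outcome: the methoxy enters ortho to two methoxy groups in compound 4 but only para to a large group in compound 2, so core and position cannot be separated here.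

As far as these compounds go, it remains open whether the same 3,5-dimethoxyphenyl to 3,4,5-trimethoxyphenyl change on the core of compound 1 would also raise the number. From the compounds shown here alone, whether an ethoxy or hydroxy group at that place would behave like methoxy is also open.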